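Ethynyl for bromo on the fused ring: compound 3

A few compounds are considered here, and "the series" means these few. Any claim that something is new, unique, unknown or untested is made for them only; others in the source may bear on it.

Measured so far:
compound 1 `CC(C)(C)c1cc(NC(=O)Nc2ccc(-c3cn4ccc(Cl)cc4n3)cc2)no1`: in a functional assay on MV4-11 cells (Homo sapiens) for cytotoxicity, read by MTT assay, with a stated time of 72 h (a higher number here means a weaker inhibitor, a lower number a stronger inhibitor), compound 1 gives 5.91 nM
compound 2 `CC(C)(C)c1cc(NC(=O)Nc2ccc(-c3cn4ccc(Br)cc4n3)cc2)no1`: in this assay compound 2 gives 9.59 nM

For the measured compounds named here, compound 2 and compound 1 sit within the scatter of each other, the only step so far being a 1.6-fold higher number from compound 1 to compound 2 (0.21 log units; within the scatter). Compound 3 `C#Cc1ccn2cc(-c3ccc(NC(=O)Nc4cc(C(C)(C)C)on4)cc3)nc2c1` is not yet measured and differs from compound 2 in one place: ethynyl in place of bromo on an aromatic carbon. Going by the values given here, the one measured step at this position, a 1.6-fold higher number from compound 1 to compound 2 (0.21 log units; within the scatter), exchanges chloro for bromo and stays within the scatter; no measured step brings in ethynyl, so its effect here is untested. The step from compound 2 to compound 3 is therefore expected to stay within the scatter, a 1.0-fold higher number from compound 2 to compound 3 (0.02 log units; within the scatter). Compound 3 is estimated at 10 nM, with a range from 4 nM to 30 nM.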

Compound 3, half-maximal inhibitory concentration: 3.46 nM
Compound 3: middle estimate off by 2.9-fold (0.46 log units), on the high side; the whole stated range lies above it.
By their numbers in this assay, from the lowest: compounds 3, 1 and 2 (each within the scatter of the next, the first and the last beyond it).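

In this assay, the position opposite the ring nitrogen now gives a step beyond the scatter (a 2.8-fold lower number from compound 2 to compound 3 (0.44 log units; beyond the scatter)), which the exchange of chloro for bromo did not give. Against the chloro compound, ethynyl stays within the scatter (a 1.7-fold lower number from compound 1 to compound 3 (0.23 log units; within the scatter)), so the modest step separates ethynyl from bromo only, and ethynyl is tolerated here as well as chloro. No measured evidence accounts for the step. Open, as far as these compounds go, is how an amine, a methoxy group or a longer alkyne chain at this position would read, and whether ethynyl keeps this standing in other cell lines.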